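Changing the aryl group on the sulfonyl sulfur

A few compounds are considered here, and "the series" means these few. Any claim that something is new, unique, unknown or untested is made for them only; others in the source may bear on it.

Measured compounds in a functional assay on PC-3 cells (Homo sapiens) for inhibition; a lower number here means a stronger inhibitor, a higher number a weaker inhibitor:
- compound 1, `COc1cc2nc(N3CCN(S(=O)(=O)c4ccccc4[N+](=O)[O-])CC3)nc(N)c2cc1OC`: 35000 nM
- compound 2, `COc1cc2nc(N3CCN(S(=O)(=O)c4ccc([N+](=O)[O-])cc4)CC3)nc(N)c2cc1OC`: 36000 nM
- compound 3, `COc1cc2nc(N3CCN(S(=O)(=O)c4ccc(N)cc4N)CC3)nc(N)c2cc1OC`: 67000 nM

Compound 3 gives the highest of the three numbers in this assay, but its distance to the other two is small: the step of a 1.9-fold higher number from compound 1 to compound 3 (0.28 log units; within the scatter) and the step of a 1.9-fold higher number from compound 2 to compound 3 (0.27 log units; within the scatter) both lie within the scatter, as does the step of a 1.0-fold higher number from compound 1 to compound 2 (0.01 log units; within the scatter) between the two nitrophenyl compounds. On these numbers, compound 3 is not separable from compound 1 or compound 2.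

Compound 4, `COc1cc2nc(N3CCN(S(=O)(=O)c4ccc5ccccc5c4)CC3)nc(N)c2cc1OC`, continues the same kind of variation. Its difference from compound 3 is naphthalen-2-yl in place of 2,4-diaminophenyl on a sulfonyl sulfur. Among the measured compounds shown here, no measured step involves a naphthalen-2-yl group, so none of the three steps bears on the change directly. All three do, however, exchange the aryl group on the same sulfonyl sulfur, and each of them stayed within the scatter. For the measured compounds named here, that is the only guidance available, and it points to no step beyond the scatter in this assay for compound 4 either, in no particular direction.

On that basis the estimated step is a 1.3-fold lower number from compound 3 to compound 4 (0.13 log units; within the scatter). Compound 4 is therefore expected to give about 50000 nM, with a range from 15000 nM to 160000 nM.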

Compound 4, half-maximal inhibitory concentration: 15000 nM
For compound 4 the middle estimate is 3.3-fold (0.52 log units) above the measured one; the measured number falls inside the stated range.
By their numbers in this assay, from the lowest: compound 4; then compounds 1, 2 and 3 (each within the scatter of the next).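

In this assay, among the compounds shown here, the aryl group on the sulfonyl sulfur now moves the number beyond the scatter, which no exchange among the earlier compounds did: the lower number comes with naphthalen-2-yl in place of 2,4-diaminophenyl (a 4.5-fold lower number from compound 3 to compound 4 (0.65 log units; beyond the scatter)), of 4-nitrophenyl (a 2.4-fold lower number from compound 2 to compound 4 (0.38 log units; beyond the scatter)) and of 2-nitrophenyl (a 2.3-fold lower number from compound 1 to compound 4 (0.37 log units; beyond the scatter)). All three steps are modest and run the same way, so the position does respond to the aryl group, although the three phenyl compounds remain within the scatter of their neighbours. In the exchange with 2,4-diaminophenyl, a second six-membered aromatic ring enters while the hydrogen-bond donors and acceptors of that group leave, and nothing at hand explains the steps or tells these changes apart.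

The compounds shown leave open whether the second ring matters in itself or whether any aryl group without nitro or amino substituents would do as well, a question that an unsubstituted phenyl group would address. Also open, going by these compounds, is whether naphthalen-1-yl or a biphenyl group on the same sulfur would lower the number further.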